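The source may hold more compounds than are shown below. What is called first, only, known or untested is meant among the compounds shown, and "the series" means these compounds.

In a physicochemical assay for solubility, in phosphate buffer, at pH 6.8 (a lower number here means a less soluble compound, a higher number a more soluble compound), three compounds share one core. Compound 1 `O=C(C1=C(O)C(=O)N(c2ccc(-c3ccon3)cc2)C1C1CCCCC1)c1ccc(CO)cc1` reaches a limit of the assay, > 50000 nM. Compound 2 `COc1ccc(C(=O)C2=C(O)C(=O)N(c3ccc(-c4ccon4)cc3)C2c2ccccc2OC)cc1` gives 34700 nM, and compound 3 `COc1ccccc1C1C(C(=O)C(C)(C)C)=C(O)C(=O)N1c1ccc(-c2ccon2)cc1` gives 29600 nM; the step of a 1.2-fold lower number from compound 2 to compound 3 (0.07 log units; within the scatter) keeps these two within the scatter. Compound 3 thus holds the lowest of the two numbers, and the remaining entry is a limit.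

Compound 4 `CC(C)(C)C(=O)C1=C(O)C(=O)N(c2ccc(-c3ccon3)cc2)C1c1ccccc1OCCO` differs from compound 3 by hydroxymethyl in place of hydrogen on a saturated chain carbon bound to an oxygen on an aromatic ring; read one bond further out, methoxy becomes 2-hydroxyethoxy. Among the measured compounds shown here, no measured step touches this position, since the step from compound 2 to compound 3 concerns the carbonyl substituent, so the data give no direct guide. Compound 4 is expected to show a step of a 1.6-fold higher number from compound 3 to compound 4 (0.21 log units; within the scatter), with an estimated value of 48000 nM spanning 22000 nM to 100000 nM.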

Compound 4, solubility: > 50000 nM
Compound 4: only a limit was reported; the forecaster's own chance of this, stated with the estimate: 40%; at least 1.0-fold (0.01 log units) between middle value and limit.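

Methoxy to 2-hydroxyethoxy is the first change shown at this place, and it gives an at least 1.6-fold higher number from compound 3 to compound 4 (0.22 log units; that floor lies within the scatter). The reading for compound 4 in this assay is a limit, not a number: the limit of > 50000 nM in this assay, at which 2 of the 4 values shown sit.
So this change brings no fall in the number, while the true size of the step stays unread.

Still open, on these data alone, is how a carboxylic acid or an amine at the end of this chain, or a longer chain, would read, and whether any of them would give a number rather than a limit.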